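The source may report more compounds than this note shows. Statements on the series, on what has been measured and on what is new or still open speak of the compounds shown alone.

Compound 3 `Cc1c(CC(=O)O)c2ccsc2n1S(=O)(=O)c1ccc(F)cc1` is the strongest of the three measured compounds in an assay on HEK293 cells for displacement of a labelled ligand from prostaglandin D2 receptor 2 (Homo sapiens) (a higher number here means a weaker inhibitor, a lower number a stronger inhibitor), where compound 3 gives 1630 nM. Compound 1 `CS(=O)(=O)c1ccc(S(=O)(=O)n2cc(CC(=O)O)c3ccsc32)cc1` gives 4000 nM in this assay, and compound 2 `CS(=O)(=O)c1ccc(S(=O)(=O)n2cc(CC(=O)O)c3sccc32)cc1` gives 5000 nM; both gaps to compound 3 lie beyond the scatter, and the three compounds differ from one another in more than one place, so no single step can be read from them.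

Compound 4 `Cc1c(CC(=O)O)c2ccsc2n1S(=O)(=O)c1ccc(S(C)(=O)=O)cc1` is not yet measured. It differs from compound 3 in one place: methylsulfonyl in place of fluoro on an aromatic carbon. Compound 1 and compound 2 carry a methylsulfonyl group on related cores and sit at higher numbers than compound 3, but their cores lack the methyl of compound 3, so they do not isolate this change.

The step from compound 3 to compound 4 is expected to be small, most likely a modest weakening a 1.5-fold higher number from compound 3 to compound 4 (0.19 log units; within the scatter) that may not exceed the scatter. Compound 4 is therefore estimated at 2500 nM in this assay, within a range from 800 nM to 8000 nM.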

Compound 4, half-maximal inhibitory concentration: 90 nM
For compound 4 the middle estimate is 28-fold (1.44 log units) above the measured one, and the stated range ends above it.
By their numbers in this assay, from the lowest: compound 4; then compound 3; then compounds 1 and 2 (each within the scatter of the next).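

In this assay, methylsulfonyl in place of fluoro on the aromatic carbon para to a large group gives an 18-fold lower number from compound 3 to compound 4 (1.26 log units; beyond the scatter), so this position responds strongly to the change when the methyl is present, which compounds 1 and 2, lacking that methyl, did not reveal. With methylsulfonyl held fixed, methyl in place of hydrogen on an aromatic carbon gives a 44-fold lower number from compound 1 to compound 4 (1.65 log units; beyond the scatter), so the low number of compound 4 depends on both groups being present. Nothing measured here explains either step.

Going by these compounds, it remains open whether ethylsulfonyl or an amine at the same position would keep a number this low. Also open, on these data alone, is whether the methyl step would be as large with fluoro in place of methylsulfonyl.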